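The compounds below may be only part of what the source reports. "The series", "measured", "known", "first", "only" and "open" are said of these compounds alone.

Measured compounds in an assay on cells for displacement of a labelled ligand from corticotropin-releasing factor receptor 1 (Homo sapiens), with a stated time of 100 min; on this read-out lower numbers stand for stronger inhibition and higher numbers for weaker inhibition: compound 1 `C=CCN(CCC)Cc1c(C(F)(F)F)nc2n(-c3c(C)cc(C)cc3C)c(Cl)cn12` gives 4.5 nM; compound 2 `CCCN(Cc1ccccc1)Cc1c(C(F)(F)F)nc2n(-c3c(C)cc(C)cc3C)c(Cl)cn12` gives 170 nM.

Compound 2 stands as the weaker of the two, the gap being a 38-fold higher number from compound 1 to compound 2 (1.58 log units; beyond the scatter). Compound 3 `CCCN(Cc1ccc(Cl)cc1)Cc1c(C(F)(F)F)nc2n(-c3c(C)cc(C)cc3C)c(Cl)cn12` differs from compound 2 by chloro in place of hydrogen on an aromatic carbon. For the measured compounds named here, no measured step bears on a substituent placed on the benzyl ring; the single step known concerns the vinyl-to-phenyl exchange and says nothing about aromatic substitution. The step from compound 2 to compound 3 is therefore expected to stay within the scatter, as a 1.1-fold lower number from compound 2 to compound 3 (0.05 log units; within the scatter). Compound 3 is estimated at 150 nM, between 50 nM and 500 nM.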

Compound 3, inhibition constant: 28 nM
Compound 3: the middle estimate sits 5.4-fold (0.73 log units) above what was measured, outside the stated range (below it).
By their numbers in this assay, from the lowest: compound 1; then compound 3; then compound 2.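

Chloro on the phenyl ring gives a 6.1-fold lower number from compound 2 to compound 3 (0.78 log units; beyond the scatter) in this assay and so shows that this ring, unsubstituted in the earlier compounds, responds to substitution. The 4-chlorophenyl group still falls short of vinyl, with a 6.2-fold higher number from compound 1 to compound 3 (0.79 log units; beyond the scatter) remaining, so chloro recovers only part of the loss seen on going to phenyl. Nothing available here explains this gain.

On these data alone, whether fluoro, methyl or methoxy at the same place would act as chloro does stays open. So does the outcome of chloro on the other carbons of the ring.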